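Cytotoxicity notes on a triazole series: compound 4

The source may hold more compounds than are shown below. What is called first, only, known or untested is meant among the compounds shown, and "the series" means these compounds.

Measured compounds in an ADME assay on HEK293 cells (Homo sapiens) for cytotoxicity, read by sulforhodamine B assay, with a stated time of 48 h, tested at 10 uM; on this read-out lower numbers stand for less inhibition and higher numbers for more inhibition at the one concentration tested (going by the name of the read-out):
compound 1 `COc1nc2ccc(Br)cc2cc1C(c1ccccc1)n1cc(-c2ccc(Br)cc2)nn1`, 6.28%
compound 2 `COc1nc2ccc(Br)cc2cc1C(c1ccccc1)n1cc(CCCCCO)nn1`, 7.96%
compound 3 `COc1nc2ccc(Br)cc2cc1C(c1ccccc1)n1cc(-c2ccc(F)cc2)nn1`, 4.04%

All three compounds share the same core and differ only in the group on the five-membered aromatic ring. Compound 2 stands highest of the three numbers, but its nearest neighbour is compound 1, with a number 1.7 percentage points higher from compound 1 to compound 2 (within the scatter), and its furthest is compound 3, with a number 3.9 percentage points lower from compound 2 to compound 3 (within the scatter); neither separation is beyond the scatter, so the three values are not distinguishable in this assay.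

Compound 4 `CCOC(=O)c1cn(C(c2ccccc2)c2cc3cc(Br)ccc3nc2OC)nn1` is the next member. Relative to compound 2 the change is ethoxycarbonyl in place of 5-hydroxypentyl on an aromatic carbon. Going by the values given here, the steps that bear on it are those that already exchanged the group at this position: a number 1.7 percentage points higher from compound 1 to compound 2 (within the scatter) and a number 3.9 percentage points lower from compound 2 to compound 3 (within the scatter), both within the scatter, as is a number 2.2 percentage points lower from compound 1 to compound 3 (within the scatter). Three different groups at this position have left the read-out flat, so no step beyond the scatter is expected in this assay for the ethoxycarbonyl either; the expected step from compound 2 is a number 2 percentage points lower from compound 2 to compound 4 (within the scatter). Compound 4 is therefore estimated at 6% in this assay, with a range from 0% to 15%.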

Compound 4, a percentage reported as inhibition, at one concentration (the size of the read-out at that concentration, not a potency): 2%
The estimate for compound 4 lay 4 percentage points above the measured number, and the stated range covers the measured number.
By their numbers in this assay, from the lowest: compounds 4, 3, 1 and 2 (each within the scatter of the next).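

In this assay, ethoxycarbonyl on the aromatic carbon of the five-membered ring adds a non-ring group with a carbonyl to the set, and all three of its exchanges stay flat: a number 6 percentage points lower from compound 2 to compound 4 (within the scatter) against 5-hydroxypentyl, a number 2 percentage points lower from compound 3 to compound 4 (within the scatter) against 4-fluorophenyl and a number 4.3 percentage points lower from compound 1 to compound 4 (within the scatter) against 4-bromophenyl. The step from 5-hydroxypentyl is the first to show that a non-ring group with 1 hydrogen-bond donor can give way to one with 0 donors and 2 acceptors without a step beyond the scatter, so the read-out at this position does not depend on that donor among these compounds. Nothing available explains why the read-out stays flat across these four groups.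

The compounds shown leave open whether an amine, a carboxylic acid or a much longer chain at this position would give a step beyond the scatter in this assay. They also leave open whether the same flat picture would hold at other concentrations, since a single tested concentration gives the size of the read-out there and no potency.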